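A few compounds are considered here, and "the series" means these few. Any claim that something is new, unique, unknown or untested is made for them only; others in the source may bear on it.

Measured so far in a functional assay on LNCaP cells (Homo sapiens) for antiproliferative activity; on this read-out higher numbers stand for weaker inhibition and lower numbers for stronger inhibition:
compound 1 `Cn1ncc(Cl)c1-c1cc(C(=O)N[C@@H]2CN[C@H](CCN3CCCC3)C[C@H]2c2ccc(Cl)c(Cl)c2)oc1Cl` gives 1920 nM
compound 2 `Cn1ncc(Cl)c1-c1cc(C(=O)N[C@@H]2CN[C@H](CC(N)=O)C[C@H]2c2ccc(Cl)c(Cl)c2)oc1Cl` gives 160 nM
compound 3 `Cn1ncc(Cl)c1-c1cc(C(=O)N[C@@H]2CN[C@H](CC(=O)NC3CCC3)C[C@H]2c2ccc(Cl)c(Cl)c2)oc1Cl` gives 80 nM

Compound 3 has the lowest of these three numbers; its nearest neighbour is compound 2, and the difference between them, a 2.0-fold lower number from compound 2 to compound 3 (0.30 log units; within the scatter), lies within the scatter. Against compound 1 the gap is clear: a 24-fold lower number from compound 1 to compound 3 (1.38 log units; beyond the scatter).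

Compound 4 `Cn1ncc(Cl)c1-c1cc(C(=O)N[C@@H]2CN[C@H](CCO)C[C@H]2c2ccc(Cl)c(Cl)c2)oc1Cl` is the unmeasured one. It differs from compound 3 in one place: hydroxymethyl in place of cyclobutylcarbamoyl on a saturated chain carbon bound to a saturated ring carbon. Of the measured steps, only those at the same place give guidance: a 12-fold lower number from compound 1 to compound 2 (1.08 log units; beyond the scatter) and a 24-fold lower number from compound 1 to compound 3 (1.38 log units; beyond the scatter). Among the compounds with values here, no measured step involves a hydroxymethyl, so the evidence is indirect. Compound 4 is expected to give a somewhat higher number than compound 3, an expected step of a 4.0-fold higher number from compound 3 to compound 4 (0.60 log units; beyond the scatter). For compound 4 the estimate in this assay is 320 nM, with a range from 80 nM to 1300 nM.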

Compound 4, half-maximal inhibitory concentration: 160 nM
Beside the measured number, compound 4's estimate is 2.0-fold (0.30 log units) above it, and the stated range covers the measured number.
By their numbers in this assay, from the lowest: compounds 3, 2 and 4 (each within the scatter of the next); then compound 1.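

In this assay, a small hydroxymethyl does as well as either amide on this saturated chain carbon bound to a saturated ring carbon, with a 2.0-fold higher number from compound 3 to compound 4 (0.30 log units; within the scatter) and no change at the digits printed from compound 2 to compound 4 (within the scatter). Neither the amide carbonyl nor the cyclobutyl ring is therefore needed to keep the number in this range. Only the pyrrolidin-1-yl group stands apart, with hydroxy in its place giving a 12-fold lower number from compound 1 to compound 4 (1.08 log units; beyond the scatter).

Nothing here explains why these groups rank as they do. Going by these compounds, how a carboxylic acid, a primary amine or a longer chain ending in hydroxy would fare at this place remains open.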